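The compounds below may be only part of what the source reports. "The series", "measured", "known", "first", "only" and "open" are said of these compounds alone.

Among the measured compounds shown here, compound 2 `CCCCNc1nc(NCc2ccc(C(=O)Nc3ccc(F)cc3)cc2)c2ccccc2n1` stands as the lowest of the two numbers measured so far in a functional assay on SW480 cells (Homo sapiens) for inhibition, read by luminescence and resazurin assay, with a stated time of 3 days; a lower number here means a stronger inhibitor, a higher number a weaker inhibitor; in that assay compound 2 gives 1000 nM. For the measured compounds named here, its only neighbour is compound 1 `C=CCNc1nc(NCc2ccc(C(=O)Nc3ccc(F)cc3)cc2)c2ccccc2n1`, which in this assay gives 11000 nM. Going by the values given here, the single measured step, an 11-fold lower number from compound 1 to compound 2 (1.04 log units; beyond the scatter), shows that a change to the chain on the amine of the shared core can move the number a long way. Compound 3 `CN(C)c1nc(NCc2ccc(C(=O)Nc3ccc(F)cc3)cc2)c2ccccc2n1` differs from compound 2 at that same position: dimethylamino in place of butylamino on an aromatic carbon. The measured step concerns a chain that keeps its hydrogen-bond donor, whereas here the donor is lost and the group becomes smaller, so that step bears on the new one only loosely. A step toward a weaker inhibitor is expected for compound 3, of size a 3.5-fold higher number from compound 2 to compound 3 (0.54 log units; beyond the scatter). Compound 3 is therefore estimated at 3500 nM, with a range from 900 nM to 15000 nM.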

Compound 3, half-maximal inhibitory concentration: 2600 nM
Estimate against measurement, compound 3: 1.3-fold (0.13 log units) above, and the stated range covers the measured number.
By their numbers in this assay, from the lowest: compound 2; then compound 3; then compound 1.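

In this assay, the change to dimethylamino removes the hydrogen-bond donor and shortens the group, yet it costs only a modest amount: a 2.6-fold higher number from compound 2 to compound 3 (0.41 log units; beyond the scatter). The same group compares well with the allyl chain, which keeps its donor: a 4.2-fold lower number from compound 1 to compound 3 (0.63 log units; beyond the scatter). A donor at this aromatic carbon is therefore not needed to reach this range of numbers, and compound 1 shows that having one does not ensure a low number; nothing measured here explains this order.

Going by these compounds, what remains open is whether the chain or the donor matters more at this position, since butylamino and dimethylamino differ in both. A methylamino group, a butyl chain with a methyl on the same nitrogen, or a longer chain such as hexylamino would help to separate the two.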